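Thiadiazole-to-oxadiazole swap with chlorophenyl on the shared core

A few compounds are considered here, and "the series" means these few. Any claim that something is new, unique, unknown or untested is made for them only; others in the source may bear on it.

Measured in a functional assay on Hs-578T cells (Homo sapiens); on this read-out higher numbers stand for weaker inhibition of growth and lower numbers for stronger inhibition of growth:
compound 1 `COc1cc(CSc2cc(Cl)c(-c3nnc(-c4ccc(Cl)cc4)s3)cc2S(=O)(=O)NC(=N)NO)cc(OC)c1OC` gives 8130 nM
compound 2 `COc1cc(CSc2cc(Cl)c(-c3nc(-c4ccccc4)no3)cc2S(=O)(=O)NC(=N)NO)cc(OC)c1OC` gives 7410 nM
compound 3 `COc1cc(CSc2cc(Cl)c(-c3nnc(-c4ccccc4)s3)cc2S(=O)(=O)NC(=N)NO)cc(OC)c1OC` gives 3310 nM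

Compound 3 holds the lowest number of the three in this assay; compound 2 sits nearer to it and compound 1 furthest, both steps beyond the scatter.

Compound 4 `COc1cc(CSc2cc(Cl)c(-c3nc(-c4ccc(Cl)cc4)no3)cc2S(=O)(=O)NC(=N)NO)cc(OC)c1OC` is not yet measured. Its change from compound 3 is 3-(4-chlorophenyl)-1,2,4-oxadiazol-5-yl in place of 5-phenyl-1,3,4-thiadiazol-2-yl on an aromatic carbon.

Among the measured compounds shown here, two measured steps bear on it, each covering one part of the change. The ring swap ran a 2.2-fold lower number from compound 2 to compound 3 (0.35 log units; beyond the scatter), so reversing it should raise the number again. The chloro change ran a 2.5-fold lower number from compound 1 to compound 3 (0.39 log units; beyond the scatter), and compound 4 takes the chloro back. Read together, both parts point the same way, towards a higher number. Against simple addition stands a 1.1-fold lower number from compound 1 to compound 2 (0.04 log units; within the scatter), which shows the two changes made together did not add up there; the estimate is therefore kept below a full sum of both steps, with a wide range.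

Compound 4 is expected to give 12000 nM in this assay, within 5000 nM to 30000 nM, an estimated step of a 3.6-fold higher number from compound 3 to compound 4 (0.56 log units; beyond the scatter).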

Compound 4, concentration for 50% growth inhibition: 4170 nM
Estimate against measurement, compound 4: 2.9-fold (0.46 log units) above, outside the stated range (below it).
By their numbers in this assay, from the lowest: compounds 3, 4, 2 and 1 (each within the scatter of the next, the first and the last beyond it).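

In this assay, exchanging 5-phenyl-1,3,4-thiadiazol-2-yl for 3-(4-chlorophenyl)-1,2,4-oxadiazol-5-yl, on the aromatic carbon ortho to the chloro group, leaves the read-out within the scatter: a 1.3-fold higher number from compound 3 to compound 4 (0.10 log units; within the scatter). With the oxadiazolyl group in place, adding the chloro also stays within the scatter, a 1.8-fold lower number from compound 2 to compound 4 (0.25 log units; within the scatter), as does the swap of the two chlorophenyl-bearing groups, a 1.9-fold lower number from compound 1 to compound 4 (0.29 log units; within the scatter). The chloro step is therefore not transferable between the thiadiazolyl and oxadiazolyl groups: the same change on two cores in this assay, a 2.5-fold lower number (0.39 log units; beyond the scatter) from compound 1 to compound 3 and a 1.8-fold higher number (0.25 log units; within the scatter) from compound 4 to compound 2, 4.4-fold (0.64 log units) apart, beyond the scatter of two such steps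

Open, on these data alone, is how an amine or a carboxylic acid in place of that chloro would read with either group. Also open, as far as these compounds go, is whether the gap between the two chloro steps would hold for a methoxy group in place of the chloro.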